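The compounds below may be only part of what the source reports. "The series", "measured", "known", "first", "only" and "open" are said of these compounds alone.

Working notes on the series. In a functional assay on PC-3 cells (Homo sapiens) for cytotoxicity, read by MTT assay, with a stated time of 48 h (on this read-out lower numbers stand for stronger inhibition and higher numbers for weaker inhibition), compound 1 (`COc1ccc(-c2c[nH]c(=O)n2-c2cc(OC)c(OC)c(OC)c2)cc1N`) gives 49800 nM, compound 2 (`COc1cc(-n2c(-c3ccc(Br)cc3)cn(C(C)=O)c2=O)cc(OC)c1OC`) gives 3100 nM and compound 3 (`COc1cc(-n2c(-c3ccc([N+](=O)[O-])cc3)cn(C(C)=O)c2=O)cc(OC)c1OC`) gives 32900 nM. Compound 3 thus lies within the scatter of compound 1, while its number stands well above that of compound 2.

The next compound is compound 4 (`COc1ccc(-c2cn(C(C)=O)c(=O)n2-c2cc(OC)c(OC)c(OC)c2)cc1OC`), which has 3,4-dimethoxyphenyl in place of 4-nitrophenyl on an aromatic carbon. For the measured compounds named here, one measured step bears on this place, an 11-fold higher number from compound 2 to compound 3 (1.03 log units; beyond the scatter), and it is large and beyond the scatter. That step brought the 4-nitrophenyl group in, and the present change takes it out again. Going by the values given here, no measured compound carries the 3,4-dimethoxyphenyl group, so the size of the change stays uncertain. Given an 11-fold higher number from compound 2 to compound 3 (1.03 log units; beyond the scatter), a lower number is expected in this assay, though by less than that step. The expected change is a 3.3-fold lower number from compound 3 to compound 4 (0.52 log units; beyond the scatter). For compound 4 the estimate is 10000 nM, with an expected range of 2500 nM to 40000 nM.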

Compound 4, half-maximal inhibitory concentration: > 50000 nM
Compound 4: only a limit was reported (the forecaster's own chance of this, stated with the estimate: 5%); middle value at least 5.0-fold (0.69 log units) from the limit.
By their numbers in this assay, from the lowest: compound 2; then compounds 3 and 1 (each within the scatter of the next). At a limit, above all of these: compound 4.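

Compound 4 stands at a limit of the assay in this assay: the limit of > 50000 nM in this assay, at which 1 of the 4 values shown sits.

Even so, the comparison with the 4-bromophenyl compound can be read, an at least 16-fold higher number from compound 2 to compound 4 (1.20 log units; beyond the scatter), so on this aromatic carbon 3,4-dimethoxyphenyl, like 4-nitrophenyl, gives a much higher number than 4-bromophenyl. The comparison with the 4-nitrophenyl compound gives only a floor, an at least 1.5-fold higher number from compound 3 to compound 4 (0.18 log units; that floor lies within the scatter), which lies within the scatter, so the order of these two groups stays undecided.

As far as these compounds go, how far the true value of compound 4 lies past its limit remains open. Also open, from the compounds shown here alone, is how 4-chlorophenyl or 4-aminophenyl would read on the shared core with the acetyl group, and thus whether the lower number of compound 2 is particular to the bromo group.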